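Swapping a Chain Amine: Expected Cytotoxicity of Compound 4

The compounds below may be only part of what the source reports. "The series", "measured", "known", "first", "only" and "open" are said of these compounds alone.

Compound 1 `COc1cc2c(Nc3nc4ccc(C(=O)Nc5c(C)cccc5C)cc4s3)ncnc2cc1OCCCN1CCCC1` in a functional assay on NCI-H661 cells (Homo sapiens) for cytotoxicity, read by WST assay, with a stated time of 72 h (on this read-out higher numbers stand for weaker inhibition and lower numbers for stronger inhibition), gives > 100000 nM, which is a limit of the assay rather than a number.
Compound 2 `CCN(CC)CCCOc1cc2ncnc(Nc3nc4ccc(C(=O)Nc5c(C)cccc5C)cc4s3)c2cc1OC` in this assay gives 66500 nM.
Compound 3 `CCN(CC)CCCOc1cc2ncnc(Nc3nc4ccc(C(=O)Nc5c(C)cc(C)cc5C)cc4s3)c2cc1OC` in this assay gives 7300 nM.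

Compound 3 thus holds the lowest of the two numbers measured, the methyl step giving a 9.1-fold lower number from compound 2 to compound 3 (0.96 log units; beyond the scatter).

Compound 4 `COc1cc2c(Nc3nc4ccc(C(=O)Nc5c(C)cc(C)cc5C)cc4s3)ncnc2cc1OCCCN1CCCC1` differs from compound 3 by pyrrolidin-1-yl in place of diethylamino on a saturated chain carbon, three bonds along the chain from an oxygen on an aromatic ring. Among the measured compounds shown here, the one measured step that bears on this change is its reverse, an at least 1.5-fold lower number from compound 1 to compound 2 (0.17 log units; that floor lies within the scatter), with one end resting at the limit of > 100000 nM in this assay, at which 1 of the 3 values shown sits. Undoing that change should give a step of similar size the other way, so a small rise in number is expected, likely within the scatter. Compound 4 is therefore expected to give about 12000 nM, between 5000 nM and 40000 nM. The step from compound 3 to compound 4 is estimated as a 1.6-fold higher number from compound 3 to compound 4 (0.22 log units; within the scatter).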

Compound 4, half-maximal inhibitory concentration: 9600 nM
Compound 4: the middle estimate sits 1.3-fold (0.10 log units) above what was measured, and the stated range covers the measured number.
By their numbers in this assay, from the lowest: compounds 3 and 4 (each within the scatter of the next); then compound 2. At a limit, above all of these: compound 1.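

With a measured number now at both ends, the swap of diethylamino for pyrrolidin-1-yl stays small in this assay (a 1.3-fold higher number from compound 3 to compound 4 (0.12 log units; within the scatter)), which the earlier pair could not show: the same change on two cores in this assay, an at least 1.5-fold lower number (0.17 log units; that floor lies within the scatter) from compound 1 to compound 2 and a 1.3-fold lower number (0.12 log units; within the scatter) from compound 4 to compound 3; the limit leaves it open whether they differ.
The added methyl on an aromatic carbon now appears with both chain amines (an at least 10-fold lower number from compound 1 to compound 4 (1.01 log units; beyond the scatter)): the same change on two cores in this assay, a 9.1-fold lower number (0.96 log units; beyond the scatter) from compound 2 to compound 3 and an at least 10-fold lower number (1.01 log units; beyond the scatter) from compound 1 to compound 4; the limit leaves it open whether they differ.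
Compound 1 gives > 100000 nM, which is a limit and not a number.

On these data alone, how a morpholine or a piperidine at the end of the chain would read here remains open, as does a shorter or longer chain carrying either amine.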